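Dimethylsulfamoyl Replaces Ethyl on the Side Chain

The source may report more compounds than this note shows. Statements on the series, on what has been measured and on what is new or still open speak of the compounds shown alone.

Compound 2 `CCCCn1c(=N)sc2cc(OC(F)(F)F)ccc21` was tested in a functional assay on the whole organism with Rattus norvegicus as the target (on this read-out higher numbers stand for an effect only at larger amounts of compound and lower numbers for an effect already at smaller amounts), and gives 10 mg/kg. Compound 1 `CCCc1ccc2nc(N)sc2c1` gives 6 mg/kg in this assay; the two numbers lie within the scatter of repeated measurements, so neither can be set apart from the other. Compound 3 `CN(C)S(=O)(=O)CCn1c(=N)sc2cc(OC(F)(F)F)ccc21` is not yet measured. It differs from compound 2 by dimethylsulfamoyl in place of ethyl on a saturated chain carbon, two bonds along the chain from an aromatic nitrogen. Within the data shown here, no measured pair shows what such a change does here, so the step of a 1.2-fold higher number from compound 2 to compound 3 (0.08 log units; within the scatter) is expected to stay within the scatter, if anything toward a larger dose. Compound 3 is therefore estimated at 12 mg/kg, with a range from 4 mg/kg to 35 mg/kg.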

Compound 3, dose for half-maximal effect: > 10 mg/kg
Compound 3 was reported as a limit; the forecaster's own chance of this, stated with the estimate: 10%; the middle value is on the limit's open side.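

Among these compounds, this is the first step read at this position: dimethylsulfamoyl in place of ethyl gives a number no lower from compound 2 to compound 3 (the limit leaves the size open). From the compounds shown here alone, the swap therefore did not lower the dose needed in this assay, though whether it raised that dose stays unknown. Compound 3 is reported only as a limit: the limit of > 10 mg/kg in this assay, at which 1 of the 3 values shown sits.

Going by these compounds, whether a longer chain, or an amine or a carboxylic acid at the end of the chain, would lower the dose remains open. Compound 1 differs from compound 2 in more than one place, so it cannot settle this.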